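The source may hold more compounds than are shown below. What is called first, only, known or untested is meant among the compounds shown, and "the series" means these compounds.

Measured so far in an assay on isolated protein for inhibition of Polyunsaturated fatty acid 5-lipoxygenase (Homo sapiens), read by immunoassay, with a stated time of 15 min; a lower number here means a stronger inhibitor, a higher number a weaker inhibitor:
- compound 1, `NS(=O)(=O)c1ccc2c(c1)S(=O)(=O)N=S2c1ccc(Br)cc1`: 91100 nM
- compound 2, `CCc1ccc(S2=NS(=O)(=O)c3cc([N+](=O)[O-])ccc32)cc1`: 180 nM

Compound 2 holds the lowest of the two numbers in this assay. Among the compounds with values here, its only neighbour, compound 1, sits far higher, and the gap between the two values is well beyond the scatter of repeated measurements. Within the data shown here, the two compounds differ in more than one place, so no single-point step can be read from that pair; the values show only that compound 2 is the much stronger inhibitor of the two.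

Compound 3, `CC(C)c1ccc(S2=NS(=O)(=O)c3cc([N+](=O)[O-])ccc32)cc1`, is the next point in the series. Relative to compound 2 it carries methyl in place of hydrogen on a saturated chain carbon bound to an aromatic carbon and a saturated chain carbon; cut one bond further out, the same change reads ethyl to isopropyl. Among the measured compounds shown here, no step between measured compounds of this kind exists in the set, so the expectation rests on the structural change alone, which is small. In this assay compound 3 is expected to give 200 nM, with a range from 70 nM to 600 nM. The expected step is a 1.1-fold higher number from compound 2 to compound 3 (0.05 log units; within the scatter), a move that is not expected to exceed the scatter in either direction.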

Compound 3, half-maximal inhibitory concentration: 360 nM
Beside the measured number, compound 3's estimate is 1.8-fold (0.26 log units) below it; the measured number falls inside the stated range.
By their numbers in this assay, from the lowest: compounds 2 and 3 (each within the scatter of the next); then compound 1.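

In this assay, within the data shown here, the first step that can be read is a 2.0-fold higher number from compound 2 to compound 3 (0.30 log units; within the scatter), for methyl in place of hydrogen on a saturated chain carbon bound to an aromatic carbon and a saturated chain carbon. At this place, then, the change from ethyl to isopropyl leaves compound 2 and compound 3 indistinguishable, a point the earlier pair could not show, since compound 1 differs from compound 2 in more than one place. No measurement at hand speaks to the reason for this result.

This single step does not show how far the place accepts further change: a tert-butyl group, a longer chain such as n-butyl, or an amine or carboxylic acid on the same carbon could each give a very different number. Steps from compound 1 to compound 2 or compound 3 cannot be read, so the large gap in values is not assigned to any one part of the structure, and the effect of the same ethyl to isopropyl change on another core also stays open.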